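The source may hold more compounds than are shown below. What is called first, only, known or untested is meant among the compounds shown, and "the series" means these compounds.

Measured so far in a functional assay on HeLa cells (Homo sapiens) for cytotoxicity, read by MTT assay, with a stated time of 72 h; a lower number here means a stronger inhibitor, a higher number a weaker inhibitor:

- compound 1 `Cn1ccc2c(Oc3ccc(NC(=O)c4cc5cccnc5n(-c5ccc(F)cc5)c4=O)cc3F)ncnc21`: 4250 nM
- compound 2 `Cn1ccc2c(Oc3ccc(NC(=O)c4cc5cccnc5n(-c5ccc(Cl)cc5)c4=O)cc3F)ncnc21`: 43900 nM

Of these two, compound 2 has the higher number at 43900 nM, which makes it the weaker inhibitor. Compound 3 `Cn1ccc2c(Oc3ccc(NC(=O)c4cc5cccnc5n(-c5ccc(Br)cc5)c4=O)cc3F)ncnc21` alters it in a single place: bromo in place of chloro on an aromatic carbon. In words, this is bromo in place of chloro on an aromatic carbon, para to a large group.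

Within the data shown here, only one measured step bears on this change, made on the same carbon: a 10-fold higher number from compound 1 to compound 2 (1.01 log units; beyond the scatter), a large step with chloro in place of fluoro. It shows that swapping one such atom for another can matter here, but a single step sets no trend to extend. No step beyond the scatter is therefore expected in this assay, though a move either way remains possible.

The expected value for compound 3 is 35000 nM, with an estimated range of 9000 nM to 100000 nM. The estimate amounts to a 1.3-fold lower number from compound 2 to compound 3 (0.10 log units; within the scatter).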

Compound 3, half-maximal inhibitory concentration: 33800 nM
Compound 3: middle estimate off by 1.0-fold (0.02 log units), on the high side; the range from low to high includes it.
By their numbers in this assay, from the lowest: compound 1; then compounds 3 and 2 (each within the scatter of the next).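

In this assay, going from 4-chlorophenyl to 4-bromophenyl gives a 1.3-fold lower number from compound 2 to compound 3 (0.11 log units; within the scatter) and so separates these two halogens at this position no more than the scatter allows, which the earlier pair could not show. Fluoro now stands apart from both, since bromo in place of fluoro gives an 8.0-fold higher number from compound 1 to compound 3 (0.90 log units; beyond the scatter) in the same direction as a 10-fold higher number from compound 1 to compound 2 (1.01 log units; beyond the scatter) and the large first step does not continue as a further rise from chloro to bromo. Nothing measured here says why fluoro differs from chloro and bromo at this position.

Still open, on these data alone, is how a plain hydrogen, a methoxy group, an amine or a carboxylic acid on this aromatic carbon would compare with fluoro in compound 1. Three halogens also cannot show whether any other group would bring a lower number than compound 1 gives.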